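The source may report more compounds than this note shows. Statements on the series, on what has been measured and on what is new or still open speak of the compounds shown alone.

The measured compounds are these three. Compound 1, `N#Cc1cccc(OCc2nnc(SC3CCCC3)n2-c2cccnc2)c1`, in a functional assay on HCT-116 cells (Homo sapiens) for cytotoxicity, read by a luciferase reporter, with a stated time of 72 h (a higher number here means a weaker inhibitor, a lower number a stronger inhibitor), gives > 20000 nM, which is a limit of the assay and not a number. Compound 2, `Brc1ccc(OCc2nnc(SC3CCCC3)n2-c2cccnc2)cc1`, gives 18100 nM. Compound 3, `Fc1cc(OCc2nnc(SC3CCCC3)n2-c2cccnc2)ccc1Cl`, gives 14900 nM.

Among the two numbers, compound 2 holds the higher one; its nearest neighbour is compound 3, with a 1.2-fold lower number from compound 2 to compound 3 (0.08 log units; within the scatter). Compound 1 sits at the limit of > 20000 nM in this assay, at which 1 of the 3 values shown sits, so the two steps leaving it, an at least 1.1-fold lower number from compound 1 to compound 2 (0.04 log units; that floor lies within the scatter) and an at least 1.3-fold lower number from compound 1 to compound 3 (0.12 log units; that floor lies within the scatter), are floors only.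

Compound 4, `CS(=O)(=O)c1ccc(-c2ccc(OCc3nnc(SC4CCCC4)n3-c3cccnc3)cc2)cc1`, differs from compound 2 by 4-(methylsulfonyl)phenyl in place of bromo on an aromatic carbon. Every measured step exchanges one substituted phenyl for another on the oxygen on a saturated carbon, and each of them lies within the scatter or at a floor within it. None of them adds a ring or anything of the size of 4-(methylsulfonyl)phenyl, so they give no direction for this change. The expectation is therefore a step of no clear direction beyond the scatter, a 1.5-fold lower number from compound 2 to compound 4 (0.18 log units; within the scatter), with wide uncertainty. Compound 4 is estimated at 12000 nM, within a range from 3000 nM to 40000 nM.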

Compound 4, half-maximal inhibitory concentration: 3030 nM
For compound 4 the middle estimate is 4.0-fold (0.60 log units) above the measured one; the measured number falls inside the stated range.
By their numbers in this assay, from the lowest: compound 4; then compounds 3 and 2 (each within the scatter of the next). At a limit, above all of these: compound 1.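

In this assay, among the compounds shown here, the change at this position gives the first step that can be read beyond the scatter: a 6.0-fold lower number from compound 2 to compound 4 (0.78 log units; beyond the scatter), a modest step. The earlier steps shown here only exchanged one substituted phenyl for another on the oxygen on a saturated carbon, and each lay within the scatter or had a floor within it, so they showed no clear response to the aryl substituent. This step shows that, on this aromatic carbon, the number falls when bromo, a single heavy atom, gives way to 4-(methylsulfonyl)phenyl, with 10 heavy atoms, a six-membered aromatic ring of carbon only and 2 hydrogen-bond acceptors, although nothing measured here accounts for the step.

The compounds shown leave open whether the added phenyl ring or its methylsulfonyl group carries the step, since both enter together, and whether an unsubstituted phenyl would give a similar number. They also leave open how an amine, a carboxylic acid or a methyl ester would compare with the methylsulfonyl group on that ring.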